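A few compounds are considered here, and "the series" means these few. Any claim that something is new, unique, unknown or untested is made for them only; others in the source may bear on it.

Measured in a functional assay on A549 cells (Homo sapiens) for cytotoxicity, read by MTT assay, with a stated time of 72 h; on this read-out higher numbers stand for weaker inhibition and lower numbers for stronger inhibition:
- Compound 1 `CCOc1ccc(NC2=CC(=O)c3ncncc3C2=O)cc1`: 0.16 ug/mL
- Compound 2 `O=C1C(Nc2ccc(F)cc2)=CC(=O)c2ncncc21`: 1.08 ug/mL
- Compound 3 `O=C1C(Nc2ccc(Br)cc2)=CC(=O)c2ncncc21`: 0.09 ug/mL

Compound 1 stands with compound 3 at the low end of these three numbers, and compound 2 lies well apart from both. The nearest neighbour is reached by a 1.8-fold lower number from compound 1 to compound 3 (0.25 log units; within the scatter), and the furthest by a 6.8-fold higher number from compound 1 to compound 2 (0.83 log units; beyond the scatter).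

Compound 4 `Cc1ccc(NC2=CC(=O)c3ncncc3C2=O)cc1` has not yet been measured in this assay. It differs from compound 1 by methyl in place of ethoxy on an aromatic carbon.

For the measured compounds named here, no measured compound carries methyl, so the evidence is indirect. Three steps change the group at this same carbon. Replacing ethoxy gave a 1.8-fold lower number from compound 1 to compound 3 (0.25 log units; within the scatter) with bromo but a 6.8-fold higher number from compound 1 to compound 2 (0.83 log units; beyond the scatter) with fluoro, and the exchange between the two halogens gave a 12-fold lower number from compound 2 to compound 3 (1.08 log units; beyond the scatter). A change at this carbon can therefore leave the number within the scatter or shift it substantially, and the largest shifts seen all involve compound 2. A small step towards a higher number is expected, with a modest rise possible and a value close to compound 1 equally plausible. The estimated step is a 1.9-fold higher number from compound 1 to compound 4 (0.27 log units; within the scatter). The estimate for compound 4 is 0.3 ug/mL, with an expected range from 0.08 ug/mL to 1 ug/mL.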

Compound 4, half-maximal inhibitory concentration: 0.02 ug/mL
For compound 4 the middle estimate is 15-fold (1.18 log units) above the measured one, and the stated range ends above it.
By their numbers in this assay, from the lowest: compound 4; then compounds 3 and 1 (each within the scatter of the next); then compound 2.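

In this assay, the methyl group at this aromatic carbon gives the strongest inhibition of the four compounds, with an 8.0-fold lower number from compound 1 to compound 4 (0.90 log units; beyond the scatter), a 4.5-fold lower number from compound 3 to compound 4 (0.65 log units; beyond the scatter) and a 54-fold lower number from compound 2 to compound 4 (1.73 log units; beyond the scatter). The earlier compounds had shown a number rising with fluoro and staying within the scatter with bromo, but no group had taken it clearly below that of compound 1; this change shows that the position still has room downwards, and that ethoxy with its oxygen, the hydrogen-bond acceptor counted here, is not required for a low number. Nothing measured here explains why methyl stands apart from ethoxy, bromo and fluoro.

The compounds shown leave open whether the low number belongs to methyl alone or extends to other carbon groups at this place, such as ethyl, a longer chain or trifluoromethyl, and how chloro or an amine would compare. As far as these compounds go, all four numbers also come from a single cell line, so whether the same order holds in other cells remains unknown.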